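Quinolin-6-yl in Place of Pyridin-3-yl on a Shared Core

The compounds below may be only part of what the source reports. "The series", "measured", "known", "first", "only" and "open" are said of these compounds alone.

Three compounds have been measured in a functional assay on HeLa cells (Homo sapiens) for cytotoxicity, read by MTT assay, with a stated time of 48 h; a lower number here means a stronger inhibitor, a higher number a weaker inhibitor:

compound 1, `O=C(O[C@H]1C[C@H](n2cc(F)c(=O)[nH]c2=O)O[C@@H]1COP(=O)(O)Oc1cccnc1)c1ccccc1`: 6900 nM
compound 2, `O=C(O[C@H]1C[C@H](n2cc(F)c(=O)[nH]c2=O)O[C@@H]1COP(=O)(O)Oc1ccc2ncccc2c1)c1ccccc1`: 7300 nM
compound 3, `O=c1[nH]c(=O)n([C@H]2C[C@H](O)[C@@H](COP(=O)(O)Oc3cccnc3)O2)cc1F`: 700 nM

Compound 2 differs from compound 1 in one place, (quinolin-6-yl in place of pyridin-3-yl on an oxygen). The step that this change made in this assay is a 1.1-fold higher number from compound 1 to compound 2 (0.02 log units; within the scatter), so the two values give no ground for any order between them.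

Compound 3 carries the same pair of rings as compound 1 but differs from it in the core, (hydrogen in place of benzoyl on an oxygen on a saturated carbon). Here the step is a 9.9-fold lower number from compound 1 to compound 3 (0.99 log units; beyond the scatter), and compound 3 stands with the lowest number of the three measured compounds.

Compound 4, `O=c1[nH]c(=O)n([C@H]2C[C@H](O)[C@@H](COP(=O)(O)Oc3ccc4ncccc4c3)O2)cc1F`, has not yet been measured. It stands to compound 3 as compound 2 stands to compound 1: quinolin-6-yl in place of pyridin-3-yl on an oxygen. The place of the change is described in the same words for both pairs, so it is the same change, now made on the core of compound 3 rather than that of compound 1.

Among the compounds with values here, the expectation for compound 4 rests on the one measured instance of this change, a 1.1-fold higher number from compound 1 to compound 2 (0.02 log units; within the scatter), which lay within the scatter. On that basis the step from compound 3 to compound 4 in this assay is expected to be small, a 1.1-fold higher number from compound 3 to compound 4 (0.06 log units; within the scatter). Compound 4 is therefore estimated at 800 nM, with a likely range from 400 nM to 1600 nM.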

Compound 4, half-maximal inhibitory concentration: 7300 nM
For compound 4 the middle estimate is 9.1-fold (0.96 log units) below the measured one; measured number above the stated range.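

In this assay, quinolin-6-yl in place of pyridin-3-yl on an oxygen, made on the core of compound 3, gave a 10-fold higher number from compound 3 to compound 4 (1.02 log units; beyond the scatter), so the change did not carry over from the core of compound 1 with the same size of step: the same change on two cores in this assay, a 1.1-fold higher number (0.02 log units; within the scatter) from compound 1 to compound 2 and a 10-fold higher number (1.02 log units; beyond the scatter) from compound 3 to compound 4, 9.9-fold (0.99 log units) apart, beyond the scatter of two such steps. Hydrogen in place of benzoyl on an oxygen on a saturated carbon likewise gave a 9.9-fold lower number from compound 1 to compound 3 (0.99 log units; beyond the scatter) with pyridin-3-yl in the molecule but no change at the digits printed from compound 2 to compound 4 (within the scatter) with quinolin-6-yl, so neither change has a step that can be carried alone from one compound to another here: the same change on two cores in this assay, a 9.9-fold lower number (0.99 log units; beyond the scatter) from compound 1 to compound 3 and no change at the digits printed (within the scatter) from compound 2 to compound 4, 9.9-fold (0.99 log units) apart, beyond the scatter of two such steps. This shows that, among these four compounds, the step of each change depends on what stands at the other place, but it does not show why, nor which of the two steps is the more usual for this series, since each change is seen only twice.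

The compounds shown leave open whether phenyl or naphthalen-2-yl on the oxygen whose other neighbour is phosphorus would follow pyridin-3-yl or quinolin-6-yl. They also leave open whether acetyl in place of benzoyl on the oxygen on a saturated carbon would give the same steps.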